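The compounds below may be only part of what the source reports. "The series", "measured", "known", "first", "only" and "open" are said of these compounds alone.

Compound 1 `O=C(Nc1ccc(Oc2ccccc2)cc1)O/N=C1\N[C@H](CO)[C@@H](O)[C@H](O)[C@H]1O` gives in an assay on isolated protein for inhibition of alpha-galactosidase (Coffea arabica) (a lower number here means a stronger inhibitor, a higher number a weaker inhibitor), only a limit, > 100000 nM.
Compound 2 `O=C(Nc1c(F)cccc1F)O/N=C1\N[C@H](CO)[C@@H](O)[C@H](O)[C@H]1O` gives in this assay only a limit, > 100000 nM.

Compound 2 thus stands where every measured value here stands: at the limit of > 100000 nM in this assay, at which 2 of the 2 values shown sit, a limit of this assay rather than a number. Compound 3 `CSc1ccc(NC(=O)O/N=C2\N[C@H](CO)[C@@H](O)[C@H](O)[C@H]2O)cc1` differs from compound 2 in one place: 4-(methylsulfanyl)phenyl in place of 2,6-difluorophenyl on an amide-type nitrogen. Going by the values given here, with compound 2 at a limit, no measured step offers a scale, so the change from compound 2 to compound 3 is expected to stay within the scatter, a step that the limit leaves unreadable from compound 2 to compound 3. Compound 3 is estimated at 150000 nM in this assay, within 50000 nM to 500000 nM, most likely again reported only as a limit.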

Compound 3, half-maximal inhibitory concentration: > 100000 nM
Compound 3: a limit, no number; the forecaster's own chance of this, stated with the estimate: 85%; the middle value does not contradict the limit.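

Going by these compounds alone, compound 3, like compound 1 and compound 2, is reported only as a limit, so no step from either of them to compound 3 can be read: the limit of > 100000 nM in this assay, at which 3 of the 3 values shown sit. The compounds shown leave open whether any group on this amide-type nitrogen gives measurable inhibition in this assay.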